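Replacing hydroxy with 4-acetamidobutyl on the long chain

This account rests on a few compounds, and the source may have more. Where it says the series, first, only, none or still open, it means among the compounds named here.

In a functional assay on K562 cells (Homo sapiens) for antiproliferative activity (on this read-out higher numbers stand for weaker inhibition of growth and lower numbers for stronger inhibition of growth), compound 3 (`CC(C)(C)C(=O)OCC1(CO)C/C(=C\CCCCCCCCCCCO)C(=O)O1`) stands at 1.09 ug/mL as the middle of three numbers, with compound 1 (`COCCCCCCCCCCC/C=C1\CC(CO)(COC(=O)C(C)(C)C)OC1=O`) at 0.516 ug/mL on the lower side and compound 2 (`CCCCCCCCC(O)CCCCCC/C=C1\CC(CO)(COC(=O)C(C)(C)C)OC1=O`) at 7.3 ug/mL on the higher side. Compared with compound 3, compound 4 (`CC(=O)NCCCCCCCCCCCCCCC/C=C1\CC(CO)(COC(=O)C(C)(C)C)OC1=O`) carries 4-acetamidobutyl in place of hydroxy on a saturated chain carbon, ten or more bonds along the chain from a double-bonded chain carbon. For the measured compounds named here, no measured compound carries an acetamide, so chain length is the closest guide. Two measured steps alter the chain: there was a 14-fold higher number from compound 1 to compound 2 (1.15 log units; beyond the scatter) when 1-hydroxynonyl replaced 5-methoxypentyl, and a 6.7-fold lower number from compound 2 to compound 3 (0.83 log units; beyond the scatter) when 5-hydroxypentyl replaced 1-hydroxynonyl. Changing methyl to hydrogen on an oxygen gave the smaller 2.1-fold higher number from compound 1 to compound 3 (0.32 log units; beyond the scatter) and says little about an amide. Going by the values given here, compound 2 at 7.3 ug/mL is the only measured compound with a chain longer than that of compound 3, so a move toward weaker growth inhibition is expected. The expected step is a 2.3-fold higher number from compound 3 to compound 4 (0.36 log units; beyond the scatter) with its size uncertain. For compound 4 the estimated value in this assay is 2.5 ug/mL with 0.6 ug/mL to 10 ug/mL as the expected range.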

Compound 4, concentration for 50% growth inhibition: 3.38 ug/mL
For compound 4 the middle estimate is 1.4-fold (0.13 log units) below the measured one; the range from low to high includes it.
By their numbers in this assay, from the lowest: compound 1; then compound 3; then compound 4; then compound 2.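

In this assay, hydroxy on a saturated chain carbon can give way to the far larger 4-acetamidobutyl with only a modest loss: the change gives a 3.1-fold higher number from compound 3 to compound 4 (0.49 log units; beyond the scatter) and remains a measurable shift. Measured against methoxy at the same place, the same group gives a 6.6-fold higher number from compound 1 to compound 4 (0.82 log units; beyond the scatter) and so also lies on the weaker side. Growth inhibition therefore weakens in both comparisons but does not disappear, with compound 4 still giving 3.38 ug/mL in this assay as its number.

No evidence at hand accounts for these shifts. The compounds shown do not separate the added chain length from the acetamide itself, and a longer chain ending in plain hydroxy, an amine or a carboxylic acid would help to tell the two apart.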